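Fluorine Added to Compound 2: What Dose to Expect

The source may hold more compounds than are shown below. What is called first, only, known or untested is meant among the compounds shown, and "the series" means these compounds.

Compound 1, `CC(C)NS(=O)(=O)Cc1noc2ccccc12`, gives 56 mg/kg in a functional assay on the whole organism (strain STD-dd) with Mus musculus as the target, in the maximal electroshock model, with a stated time of 2 h; on this read-out higher numbers stand for an effect only at larger amounts of compound and lower numbers for an effect already at smaller amounts.
Compound 2, `CN1CCN(S(=O)(=O)Cc2noc3ccccc23)CC1`, gives 57 mg/kg in this assay.
Compound 3, `CC(C)NS(=O)(=O)Cc1noc2ccc(F)cc12`, gives 38 mg/kg in this assay.

All three numbers lie within the usual scatter of one another, so compound 2 is not set apart from compound 1 or compound 3 by these data; its number simply sits alongside theirs. Compound 4, `CN1CCN(S(=O)(=O)Cc2noc3ccc(F)cc23)CC1`, has not yet been measured in this assay. It differs from compound 2 in one place: fluoro in place of hydrogen on an aromatic carbon.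

Among the compounds with values here, one measured step bears on this change. The same swap was made between compound 1 and compound 3, where it gave a 1.5-fold lower number from compound 1 to compound 3 (0.17 log units; within the scatter). That step stayed within the scatter, so on its own it gives no sign of a real shift. The same is therefore expected for compound 4: a number a little lower than that of compound 2, but not clearly different. Compound 4 is expected to give 40 mg/kg, with a range from 22 mg/kg to 75 mg/kg. This estimate means an expected 1.4-fold lower number from compound 2 to compound 4 (0.15 log units; within the scatter).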

Compound 4, dose for half-maximal effect: 100 mg/kg
The estimate for compound 4 lay 2.5-fold (0.40 log units) below the measured number; the whole stated range lies below it.
By their numbers in this assay, from the lowest: compounds 3, 1, 2 and 4 (each within the scatter of the next, the first and the last beyond it).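

In this assay, the fluoro swap now has a second reading, on the core that carries the 4-methylpiperazin-1-yl group, and it gives a 1.8-fold higher number from compound 2 to compound 4 (0.24 log units; within the scatter). Set side by side, the two readings of this swap point in opposite directions, yet neither step leaves the scatter and neither does the gap between them: the same change on two cores in this assay, a 1.5-fold lower number (0.17 log units; within the scatter) from compound 1 to compound 3 and a 1.8-fold higher number (0.24 log units; within the scatter) from compound 2 to compound 4, 2.6-fold (0.41 log units) apart, within the scatter of two such steps. So fluoro in place of hydrogen on this aromatic carbon shows no clear shift on either core, and the one step here beyond the scatter lies at the sulfonyl sulfur instead, where 4-methylpiperazin-1-yl in place of isopropylamino gives a 2.6-fold higher number from compound 3 to compound 4 (0.42 log units; beyond the scatter).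

The compounds shown leave open whether another group on this aromatic carbon, such as chloro or methoxy, would give a step that clearly stands beyond the scatter. They also leave open how a different amine on the sulfonyl sulfur, such as morpholine or a plain primary amine, would behave, and whether the modest step at the sulfur would hold on a core without fluoro.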